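Replacing a Trifluoromethylphenyl Group with Chlorophenyl: Compound 4

A few compounds are considered here, and "the series" means these few. Any claim that something is new, unique, unknown or untested is made for them only; others in the source may bear on it.

Measured so far in an assay on HEK293 cells for inhibition of Voltage-dependent T-type calcium channel subunit alpha-1G (Homo sapiens), read by fluorescence, tested at 10 uM; on this read-out higher numbers stand for more inhibition at the one concentration tested (going by the name of the read-out) and lower numbers for less inhibition:
Compound 1, `CCCc1nc(-c2ccccc2)c(CNCCN2CCN(c3cccc(C(F)(F)F)c3)CC2)o1`, gives 56.3%.
Compound 2, `CCCc1nc(-c2ccccc2)c(CNCCN2CCN(c3ccc(C)cc3)CC2)o1`, gives 48.1%.
Compound 3, `CCCc1nc(-c2ccccc2)c(CNCCN2CCN(c3ccccc3C(F)(F)F)CC2)o1`, gives 54.6%.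

Compound 3 sits second highest of the three numbers, though all three lie within the usual scatter of one another, so none can be called stronger or weaker than the rest. The new compound 4, `CCCc1nc(-c2ccccc2)c(CNCCN2CCN(c3cccc(Cl)c3)CC2)o1`, differs from compound 3 in one place: 3-chlorophenyl in place of 2-(trifluoromethyl)phenyl on an amine nitrogen in a ring.

Three earlier steps changed the same aromatic group on the same ring nitrogen. The change from compound 1 to compound 3 gave a number 1.7 percentage points lower from compound 1 to compound 3 (within the scatter), that from compound 2 to compound 3 gave a number 6.5 percentage points higher from compound 2 to compound 3 (within the scatter), and that from compound 1 to compound 2 gave a number 8.2 percentage points lower from compound 1 to compound 2 (within the scatter). Every one of these swaps left the read-out in this assay essentially unchanged. A further swap of the same kind is therefore expected to produce no step beyond the scatter, and the expected step from compound 3 to compound 4 is a number 2.6 percentage points lower from compound 3 to compound 4 (within the scatter). Compound 4 is estimated at 52%, in a range from 38% to 66%.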

Compound 4, a percentage reported as inhibition, at one concentration (the size of the read-out at that concentration, not a potency): 51.2%
Compound 4: middle estimate off by 0.8 percentage points, on the high side; low and high end bracket the measured number.
By their numbers in this assay, from the lowest: compounds 2, 4, 3 and 1 (each within the scatter of the next).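

In this assay, chloro in place of trifluoromethyl on an aromatic carbon gives a number 5.1 percentage points lower from compound 1 to compound 4 (within the scatter), the first step shown that exchanges only the substituent and keeps the rest of the aromatic group. The steps from the other two compounds, a number 3.4 percentage points lower from compound 3 to compound 4 (within the scatter) and a number 3.1 percentage points higher from compound 2 to compound 4 (within the scatter), also stay inside the scatter, so a chlorine-bearing phenyl now joins the trifluoromethyl- and methyl-bearing ones as a group that cannot be told apart at this ring nitrogen. No measurement shown here gives a reason for this flat result.

As far as these compounds go, it remains open whether a carboxylic acid or an amine on this phenyl ring, or a pyridine ring in its place, would shift the number beyond the scatter. These single-concentration readings also leave the potency of all four compounds undefined.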